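The source may report more compounds than this note shows. Statements on the series, on what has been measured and on what is new or still open speak of the compounds shown alone.

Compound 3, `CCCCCCCCC#Cc1cc2cn(COCCO)c(=O)nc2o1`, carries a chain ending in a triple bond on the shared core. In a functional assay on HEL cells (Homo sapiens), read by microscopy (on this read-out lower numbers stand for higher toxicity in this test and higher numbers for lower toxicity in this test), compound 3 gives only a limit, >= 20000 nM. It sits at the limit of >= 20000 nM in this assay, at which 1 of the 3 values shown sits. Compound 1, `CCCCCCc1cc2cn(COCCO)c(=O)nc2o1`, likewise gives only a limit in this assay, >= 400000 nM. Compound 2, `CCCCCCCc1cc2cn(COCCO)c(=O)nc2o1`, gives 400000 nM in this assay. For the measured compounds named here, the one measured step, a number no higher from compound 1 to compound 2 (the limit leaves the size open), is methyl in place of hydrogen on a saturated chain carbon, and its size cannot be read. Compound 4, `CCCCCC#Cc1cc2cn(COCCO)c(=O)nc2o1`, differs from compound 3 by hydrogen in place of propyl on a saturated chain carbon, five bonds along the chain from a triple-bonded carbon. Going by the values given here, no measured step shortens a chain in this way, so the expected size of the change is open. Compound 4 is expected to give about 100000 nM in this assay, within 20000 nM to 400000 nM. The expected step is a step that the limit leaves unreadable from compound 3 to compound 4.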

Compound 4, minimum cytotoxic concentration: >= 100000 nM
Compound 4: a limit, no number; the forecaster's own chance of this, stated with the estimate: 70%; the middle value lies on the limit itself.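

Compound 4 gives only a limit, so no new step can be read from it to compound 1, compound 2 or compound 3. The compounds shown leave open how far chain length or the triple bond shifts the number in this assay.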